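Acetoxymethyl for carbamoyl on a shared core

The source may report more compounds than this note shows. Statements on the series, on what has been measured and on what is new or still open speak of the compounds shown alone.

Among the compounds with values here, in an ADME assay on Huh-5-2 cells (Homo sapiens) for cytotoxicity, with a stated time of 3 days (a lower number here means that less compound is tolerated, a higher number that more compound is tolerated), compound 1 (`COC[C@H]1C[C@@](CC(C)C)(C(=O)O)N(C(=O)c2ccc(C(C)(C)C)c(OC)c2)[C@@H]1c1nccs1`) gives 200000 nM, the only actual number among the compounds tested so far. Compound 2 (`COC[C@H]1C[C@@](CC(C)C)(C(=O)O)N(C(=O)c2ccc(C(C)(C)C)c(OC)c2)[C@H]1C(N)=O`) gives > 120000 nM, which is a limit of the assay and not a number. Compound 3 (`COC[C@H]1C[C@@](CC(C)C)(C(=O)O)N(C(=O)c2ccc(C(C)(C)C)c(OC)c2)[C@H]1COC`) gives > 120000 nM, which is also a limit. Compound 2 therefore stands at the limit of > 120000 nM in this assay, at which 2 of the 3 values shown sit, and its true position is not known.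

Compound 4 (`COC[C@H]1C[C@@](CC(C)C)(C(=O)O)N(C(=O)c2ccc(C(C)(C)C)c(OC)c2)[C@H]1COC(C)=O`) has not yet been measured. Its difference from compound 2 is acetoxymethyl in place of carbamoyl on a saturated ring carbon, with acetoxymethyl in place of carbamoyl on a saturated ring carbon. The closest measured change is a step that the two limits leave unreadable from compound 2 to compound 3, where methoxymethyl replaces carbamoyl at that same ring carbon. That step gives no size to carry over, and it gives no direction either. Within the data shown here, the number for compound 1, 200000 nM, suggests only that this shared core can be tolerated at high concentrations in this assay.

With no readable step to draw on, the expected change a step that the limit leaves unreadable from compound 2 to compound 4 is estimated to stay within the usual scatter, with neither direction favoured. The assay may well report only a limit again. The estimated value for compound 4 is 130000 nM, with an expected range from 55000 nM to 250000 nM.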

Compound 4, half-maximal cytotoxic concentration: > 120000 nM
Compound 4: a limit, no number; the forecaster's own chance of this, stated with the estimate: 60%; the middle value does not contradict the limit.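

In this assay compound 4 gives > 120000 nM, which is a limit of the assay and not a number. The steps among compound 2, compound 3 and compound 4 therefore cannot be read, and compound 2 remains without a true position: the limit of > 120000 nM in this assay, at which 3 of the 4 values shown sit.

The compounds shown leave open whether carbamoyl, methoxymethyl and acetoxymethyl on that ring carbon differ in their effect at all.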